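A few compounds are considered here, and "the series" means these few. Any claim that something is new, unique, unknown or untested is made for them only; others in the source may bear on it.

In a functional assay on cells for positive allosteric modulation of metabotropic glutamate receptor 2 (Homo sapiens), read by fluorescence and calcium flux, with a stated time of 30 min (on this read-out higher numbers stand for an effect only at larger amounts of compound and lower numbers for an effect already at smaller amounts), three close relatives of a shared core have been measured. Compound 1 `Brc1cccc2c1nnn2CC1CC1` gives 70 nM; compound 2 `Clc1cccc2c1nnn2CC1CC1` gives 90 nM; compound 3 `Fc1cccc2c1nnn2CC1CC1` gives 1070 nM. Compound 3 thus stands at the highest number of the three: the step of a 15-fold higher number from compound 1 to compound 3 (1.18 log units; beyond the scatter) and the step of a 12-fold higher number from compound 2 to compound 3 (1.08 log units; beyond the scatter) are both beyond the scatter, whereas the step of a 1.3-fold higher number from compound 1 to compound 2 (0.11 log units; within the scatter) stays within it.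

Compound 4 `N#Cc1cccc2c1nnn2CC1CC1` differs from compound 3 by the change (cyano in place of fluoro on an aromatic carbon). The measured steps that bear on this position are the two halogen swaps leading to compound 3, each large and each pointing toward a higher number for fluoro than for bromo or chloro. Among the compounds with values here, no measured step involves cyano, so the direction is open. Within the data shown here, since the only group at this position that gave a high number was fluoro, and the two other groups tried gave clearly lower numbers, a lower number than compound 3 is expected for compound 4, but with wide uncertainty: the step of a 2.7-fold lower number from compound 3 to compound 4 (0.43 log units; beyond the scatter) is estimated. Compound 4 is therefore expected at about 400 nM in this assay, in a range from 100 nM to 2000 nM.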

Compound 4, half-maximal effective concentration: 620 nM
Compound 4: the middle estimate sits 1.6-fold (0.19 log units) below what was measured, within the range that was stated.
By their numbers in this assay, from the lowest: compounds 1 and 2 (each within the scatter of the next); then compounds 4 and 3 (each within the scatter of the next).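

In this assay, cyano in place of fluoro gives no separation beyond the scatter (a 1.7-fold lower number from compound 3 to compound 4 (0.24 log units; within the scatter)), so the high number at this position no longer belongs to fluoro alone. Cyano also stays apart from the other two groups, with modest steps in place of chloro (a 6.9-fold higher number from compound 2 to compound 4 (0.84 log units; beyond the scatter)) and bromo (an 8.9-fold higher number from compound 1 to compound 4 (0.95 log units; beyond the scatter)). The four compounds therefore fall into two sets, bromo and chloro at the lower numbers and fluoro and cyano at the higher ones, and the hydrogen-bond acceptor and extra heavy atom that enter with cyano bring no step beyond the scatter from fluoro.

Nothing given here accounts for this division into two sets. Going by these compounds, it remains open on which side an amine, a methyl group, a methoxy group or a carboxylic acid would fall at this aromatic carbon, and whether the same two sets would hold if the rest of the shared core were changed.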